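This account rests on a few compounds, and the source may have more. Where it says the series, first, only, none or still open, it means among the compounds named here.

Compound 1 `Nc1nccc2c1ncn2[C@H]1C[C@H](O)[C@@H](CO)O1` and compound 2 `CN(C)c1nccc2c1ncn2[C@H]1C[C@H](O)[C@@H](CO)O1` share a core that carries a larger attached part, while compound 3 `CN(C)c1[nH]ccc2ncnc1-2` and compound 4 `Nc1[nH]ccc2ncnc1-2` carry the bare core; the difference between the two cores is not broken down here. In a functional assay on the whole organism (Pleural cavity) with Rattus norvegicus as the target (a lower number here means that less compound is needed, a higher number that more compound is needed for the effect), compound 1 gives 10 mg/kg. In this assay compound 2 gives > 9 mg/kg, which is a limit of the assay and not a number. The change from compound 2 to compound 1, (amino in place of dimethylamino on an aromatic carbon), therefore gives a step that the limit leaves unreadable from compound 2 to compound 1, and the limit of > 9 mg/kg in this assay, at which 1 of the 3 values shown sits, hides its size. In this assay compound 3 gives 9 mg/kg, which sits within the scatter of compound 1. The same change, (amino in place of dimethylamino on an aromatic carbon), turns compound 3 into compound 4. With the measured step unreadable and compound 3 at 9 mg/kg close to compound 1 at 10 mg/kg, compound 4 is expected to give 10 mg/kg, within 4 mg/kg to 25 mg/kg. That estimate means a step of a 1.1-fold higher number from compound 3 to compound 4 (0.05 log units; within the scatter), expected to stay within the scatter, with a real chance that only a limit is reported again.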

Compound 4, dose for half-maximal effect: 8 mg/kg
For compound 4 the middle estimate is 1.3-fold (0.10 log units) above the measured one, and the stated range covers the measured number.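

In this assay, putting amino in place of dimethylamino on the bare core gives a 1.1-fold lower number from compound 3 to compound 4 (0.05 log units; within the scatter), so on this core the two groups cannot be told apart. The same change on the core with the larger attached part cannot be read, because compound 2 gives a limit of the assay and not a number: the limit of > 9 mg/kg in this assay, at which 1 of the 4 values shown sits. Among the compounds shown here, only one core therefore gives a readable step, so these results neither show that the change carries over from one core to the other nor show that it fails to.

As far as these compounds go, it remains open whether a different group on the same aromatic carbon, such as methylamino, a longer amine chain or a carboxylic acid, would separate itself from amino and dimethylamino in this whole-animal test. Also open, from the compounds shown here alone, is how much the larger attached part itself contributes, as the difference between the two cores is not broken down here.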